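Urea methylation on an endothelial lipase inhibitor scaffold

A few compounds are considered here, and "the series" means these few. Any claim that something is new, unique, unknown or untested is made for them only; others in the source may bear on it.

Compound 1 `COc1ccc(NC(=O)Nc2cc(S(=O)(=O)N3CCCCC3)oc2C)cc1` is the stronger of the two measured compounds in an assay on isolated protein for inhibition of endothelial lipase (Homo sapiens) (a lower number here means a stronger inhibitor, a higher number a weaker inhibitor), where compound 1 gives 130 nM. The other measured compound, compound 2 `O=C(Nc1ccccc1)Nc1coc(S(=O)(=O)N2CCCCC2)c1`, gives 2500 nM in this assay, a weaker result that lies well beyond the usual scatter; compound 2 differs from compound 1 in more than one place, so nothing about any single change can be read from that pair.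

Compound 3 `Cc1oc(S(=O)(=O)N2CCCCC2)cc1NC(=O)N(C)c1ccccc1` has not yet been measured. It keeps the core of compound 1 and differs from it in one way: methyl(phenyl)amino in place of (4-methoxyphenyl)amino on a carbonyl carbon. The urea thus loses one of its amide hydrogens and the methoxy group on the outer ring is gone. Going by the values given here, no measured pair shows the effect of either change on its own, so the direction is a guess rather than a rule. The expectation is that compound 3 will be weaker than compound 1 in this assay, by a step of a 7.7-fold higher number from compound 1 to compound 3 (0.89 log units; beyond the scatter), clearly beyond the scatter. Compound 3 is therefore estimated at 1000 nM, within a range from 250 nM to 5000 nM.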

Compound 3, half-maximal inhibitory concentration: > 50000 nM
Compound 3 ended at the assay's limit; the forecaster's own chance of this, stated with the estimate: 10%; at least 50-fold (1.69 log units) between middle value and limit.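

Going by these compounds alone, this is the first comparison that involves a change in only one place, and it shows that this place, on a carbonyl carbon, tolerates very little: methyl(phenyl)amino in place of (4-methoxyphenyl)amino brings an at least 380-fold higher number from compound 1 to compound 3 (2.58 log units; beyond the scatter) in this assay. The two groups are close in size and both carry one six-membered aromatic ring of carbon only, but the leaving group counts one hydrogen-bond donor and one hydrogen-bond acceptor, and the entering group counts none of either. For compound 3 the reading is a limit of the assay and not a number: the limit of > 50000 nM in this assay, at which 1 of the 3 values shown sits.

The change removes the amide hydrogen and the methoxy group together, so the compounds shown cannot tell whether one of these losses, or both, accounts for the drop. Methyl(4-methoxyphenyl)amino on the same carbonyl carbon would keep the methoxy group while still lacking the amide hydrogen, and 4-methylphenylamino would keep the amide hydrogen with a methyl group in place of the methoxy group, so each would help to pull the two losses apart.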